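The compounds below may be only part of what the source reports. "The series", "measured", "known", "first", "only" and "open" are said of these compounds alone.

Measured in a physicochemical assay for lipophilicity, using the shake flask method; a higher number here means a more lipophilic compound, a lower number a more polar compound:
- compound 1 `C[C@H](Oc1ccc2ncc(/C=C/S(=O)(=O)O)c(C3CC3)c2c1)c1c(Cl)ccc(F)c1Cl`: 2.5
- compound 2 `Cc1c(/C=C/C(=O)O)cnc2ccc(O[C@@H](C)c3c(Cl)ccc(F)c3Cl)cc12`: 3
- compound 3 `C[C@H](Oc1cccc(C2CC2)c1)c1c(Cl)ccc(F)c1Cl`: 5

Compound 2 is the second highest of the three. Its value lies beyond the scatter from both compound 1 and compound 3, the latter being the furthest from it.

Compound 4 `C[C@H](Oc1ccc2ncc(/C=C/C(=O)O)c(C#N)c2c1)c1c(Cl)ccc(F)c1Cl` carries cyano in place of methyl on an aromatic carbon, opposite the ring nitrogen: cyano in place of methyl on an aromatic carbon.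

Within the data shown here, no measured pair shows this exchange, so the expectation rests on the structural change alone. A downward move in this assay, probably beyond the scatter, is expected, estimated as a number 0.70 log units lower from compound 2 to compound 4 (beyond the scatter). For compound 4 the estimated value is 2.3, with an expected range of 1.7 to 2.8.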

Compound 4, distribution coefficient: 2.3
Compound 4: middle estimate and measured number agree at the digits printed; the measured number falls inside the stated range.
By their numbers in this assay, from the lowest: compounds 4 and 1 (each within the scatter of the next); then compound 2; then compound 3.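

In this assay cyano in place of methyl gives a number 0.70 log units lower from compound 2 to compound 4 (beyond the scatter) on this aromatic carbon, opposite the ring nitrogen and ortho to the 2-carboxyethenyl group. Among these compounds, this is the first single-place step, and it shows that the number responds to a change at this position. No measured evidence on the origin of the step is at hand.

From the compounds shown here alone, whether an amine or a methoxy group on this carbon would move the number the same way remains open. So does whether the step holds with a group other than 2-carboxyethenyl beside it.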